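This account rests on a few compounds, and the source may have more. Where it says the series, first, only, none or still open, it means among the compounds named here.

Of the compounds shown here, three sharing one core have been measured in an assay on CHO cells for displacement of a labelled ligand from 5-hydroxytryptamine receptor 1D (Homo sapiens); on this read-out lower numbers stand for stronger inhibition and higher numbers for weaker inhibition. Compound 1 `O[C@H]1Cc2ccccc2C1NC1CCN(CCCc2c[nH]c3ccc(-n4cnnc4)cc23)CC1` gives 37 nM in this assay, the highest of the three numbers. Compound 2 `CN(Cc1ccc(S(C)(=O)=O)cc1)C1CCN(CCCc2c[nH]c3ccc(-n4cnnc4)cc23)CC1` gives 18 nM, and compound 3 `CC(=O)Nc1ccc([C@H](C)NCC2CCN(CCCc3c[nH]c4ccc(-n5cnnc5)cc34)CC2)cc1` gives 0.6 nM, a value far lower than that of compound 1.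

Compound 4 `c1cncc(CNC2CCN(CCCc3c[nH]c4ccc(-n5cnnc5)cc34)CC2)c1` has not yet been measured. It differs from compound 1 in one place: (pyridin-3-yl)methyl in place of 2-hydroxy-2,3-dihydro-1H-inden-1-yl on an amine nitrogen. The nitrogen attached to the saturated ring carbon keeps its position; only the group hanging from it changes, and the hydroxy group and the stereocentre of compound 1 are gone.

Among the measured compounds shown here, no measured pair shows this exact change, so the expectation rests on the spread of the three values. The step from compound 1 to compound 4 is expected to be a 1.9-fold lower number from compound 1 to compound 4 (0.27 log units; within the scatter), a modest move toward a lower number that may not exceed the scatter. Compound 4 is estimated at 20 nM, with a likely range from 5 nM to 80 nM.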

Compound 4, half-maximal inhibitory concentration: 35 nM
Estimate against measurement, compound 4: 1.8-fold (0.24 log units) below, and the stated range covers the measured number.
By their numbers in this assay, from the lowest: compound 3; then compounds 2, 4 and 1 (each within the scatter of the next, the first and the last beyond it).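

The step of a 1.1-fold lower number from compound 1 to compound 4 (0.02 log units; within the scatter) shows that on this amine nitrogen, 2-hydroxy-2,3-dihydro-1H-inden-1-yl can give way to (pyridin-3-yl)methyl with no readable change in the number. The group that enters has fewer heavy atoms, no hydrogen-bond donor and no defined stereocentre, yet the result stays within the scatter.

On these data alone, whether a plain benzyl group or a (pyridin-4-yl)methyl group on the same nitrogen would read alike remains open. So does the separate contribution of the hydroxy group, and no available data explain why these two groups read alike.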